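This account rests on a few compounds, and the source may have more. Where it says the series, first, only, none or still open, it means among the compounds named here.

Compound 1 `CCN1CCN(C(=O)c2ccc(Nc3ncc4c(n3)N(C)C(=O)N(c3cc(NC(=O)c5cccc(C(F)(F)F)c5)ccc3C)C4)cn2)CC1`: 23.3%
Compound 2 `Cc1ccc(NC(=O)c2cccc(C(F)(F)F)c2)cc1N1Cc2cnc(Nc3cnn(C)c3)nc2N(C)C1=O`: 71.3%
Compound 3 `CCN1CCN(c2ccc(Nc3ncc4c(n3)N(C)C(=O)N(c3cc(NC(=O)c5cccc(C(F)(F)F)c5)ccc3C)C4)cn2)CC1`: 21.4%

In an ADME assay on microsomes from liver (Canis lupus familiaris) for metabolic stability, with a stated time of 30 min, tested at 1 uM (a higher number here means that more of the compound is left, a lower number that less of the compound is left), compound 2 stands highest of the three, with compound 1 and compound 3 both far lower and within the scatter of each other. Compound 4 `Cc1cc(Nc2ncc3c(n2)N(C)C(=O)N(c2cc(NC(=O)c4cccc(C(F)(F)F)c4)ccc2C)C3)n(C)n1` keeps the rest of compound 2 and changes one group: 1,3-dimethyl-1H-pyrazol-5-yl in place of 1-methyl-1H-pyrazol-4-yl on a nitrogen on an aromatic ring. Among the measured compounds shown here, the only measured step, a number 1.9 percentage points lower from compound 1 to compound 3 (within the scatter), involves 4-ethylpiperazin-1-yl in place of (4-ethylpiperazin-1-yl)carbonyl, so it offers only weak guidance. For the measured compounds named here, no measured step replaces 1-methyl-1H-pyrazol-4-yl. In this assay a slight fall, not beyond the scatter, is therefore expected, as the estimated a number 5.3 percentage points lower from compound 2 to compound 4 (within the scatter). For compound 4 the estimated value is 66%, with an expected range from 45% to 84%.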

Compound 4, percent of the compound remaining: 69.9%
Compound 4: middle estimate off by 3.9 percentage points, on the low side; the range from low to high includes it.
By their numbers in this assay, from the lowest: compounds 3 and 1 (each within the scatter of the next); then compounds 4 and 2 (each within the scatter of the next).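

In this assay, the step from 1-methyl-1H-pyrazol-4-yl to 1,3-dimethyl-1H-pyrazol-5-yl on a nitrogen on an aromatic ring gives a number 1.4 percentage points lower from compound 2 to compound 4 (within the scatter), so the two pyrazoles read alike here. Among the compounds shown here, this is the first step at this position, since the earlier step concerned only the ethylpiperazine side of the series. Nothing measured on these compounds accounts for this result. Still open, from the compounds shown here alone, is whether the same holds for a pyrazole carrying a carboxylic acid or a longer chain such as propyl. An isoxazole at this position also remains untested within the compounds shown.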